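Moving the halogen: from compound 2 to compound 3

A few compounds are considered here, and "the series" means these few. Any claim that something is new, unique, unknown or untested is made for them only; others in the source may bear on it.

Compound 1, `C=CC(=O)Nc1cccc(NC(=O)CSc2nc(Nc3ccccc3Cl)c3ccccc3n2)c1`: 10000 nM
Compound 2, `C=CC(=O)Nc1cccc(NC(=O)CSc2nc(Nc3ccccc3Br)c3ccccc3n2)c1`: 19300 nM

In a functional assay on NCI-H1975 cells (Homo sapiens) for inhibition, read by MTT assay, with a stated time of 72 h (a lower number here means a stronger inhibitor, a higher number a weaker inhibitor), compound 2 gives the highest of the two numbers, but its gap to compound 1 lies within the scatter. Compound 3, `C=CC(=O)Nc1cccc(NC(=O)CSc2nc(Nc3cccc(Cl)c3)c3ccccc3n2)c1`, carries 3-chlorophenyl in place of 2-bromophenyl on a nitrogen on an aromatic ring. Going by the values given here, the only measured step, a 1.9-fold higher number from compound 1 to compound 2 (0.29 log units; within the scatter), swaps one halogen for another at the same spot and stays within the scatter; no measured step shifts a halogen to a different spot on its ring, so the size of that part of the change is unknown. Compound 3 is therefore expected to land near its neighbours, with a 1.8-fold lower number from compound 2 to compound 3 (0.24 log units; within the scatter) as the expected step. The estimate for compound 3 is 11000 nM, ranging from 3000 nM to 40000 nM.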

Compound 3, half-maximal inhibitory concentration: 9460 nM
Estimate against measurement, compound 3: 1.2-fold (0.07 log units) above; measured number inside the range.
By their numbers in this assay, from the lowest: compounds 3, 1 and 2 (each within the scatter of the next, the first and the last beyond it).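

In this assay, moving the chlorine on its ring, with 3-chlorophenyl in place of 2-chlorophenyl, gives a 1.1-fold lower number from compound 1 to compound 3 (0.02 log units; within the scatter). Going by these compounds alone, this is the first measured shift of a halogen to a different spot, and it does not separate the two compounds. Changing the halogen and its spot together gives a 2.0-fold lower number from compound 2 to compound 3 (0.31 log units; beyond the scatter), a modest step, and no measurement available here explains it. The compounds shown leave open how 3-bromophenyl would compare, and whether a different group on this ring, such as methoxy or an amine, would give a larger step.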